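From 4-chlorophenyl to 2,4-difluorophenyl: estimating growth inhibition

This account rests on a few compounds, and the source may have more. Where it says the series, first, only, none or still open, it means among the compounds named here.

In a functional assay on OVCAR-8 cells (Homo sapiens) (a lower number here means a stronger inhibitor of growth, a higher number a weaker inhibitor of growth), compound 1 `O=S(=O)(/C=C/c1ccc(F)cc1F)Cc1ccc(Nc2ncnc3ccccc23)cc1` gives > 100000 nM as a limit
In this assay compound 2 `O=S(=O)(/C=C/c1ccc(Cl)cc1)Cc1ccc(Nc2ncnc3ccc(Br)cc23)cc1` gives 3000 nM

Among the measured compounds shown here, compound 2 at 3000 nM is the only true number so far. Compound 3 `O=S(=O)(/C=C/c1ccc(F)cc1F)Cc1ccc(Nc2ncnc3ccc(Br)cc23)cc1` has 2,4-difluorophenyl in place of 4-chlorophenyl on a double-bonded chain carbon bound to a double-bonded chain carbon. For the measured compounds named here, no measured step shows this change directly. Compound 1 also carries 2,4-difluorophenyl and its > 100000 nM is a limit, so a modest step toward weaker growth inhibition is expected in this assay here. The expected 2.0-fold higher number from compound 2 to compound 3 (0.30 log units; within the scatter) is an estimate only. The estimate for compound 3 is 6000 nM with 1500 nM to 30000 nM as its expected range.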

Compound 3, concentration for 50% growth inhibition: 100000 nM
For compound 3 the middle estimate is 17-fold (1.22 log units) below the measured one; the measured number lies above the stated range.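

The swap alone gives a 33-fold higher number from compound 2 to compound 3 (1.52 log units; beyond the scatter) in this assay with the rest of the molecule unchanged. At this position, on a double-bonded chain carbon bound to a double-bonded chain carbon, 4-chlorophenyl and 2,4-difluorophenyl are therefore far from interchangeable, which compounds 1 and 2, differing in more than one place, could not show. Bromo in place of hydrogen on an aromatic carbon gives a number no higher from compound 1 to compound 3 (the limit leaves the size open) in this assay. What this change does cannot be read, because compound 1 has only a limit: the limit of > 100000 nM in this assay, at which 1 of the 3 values shown sits.

From the compounds shown here alone, it remains open whether the chlorine, the fluorines or the fluorine count matters most. Going by these compounds, how a plain phenyl or a 4-methoxyphenyl would fare here also remains unknown.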